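A few compounds are considered here, and "the series" means these few. Any claim that something is new, unique, unknown or untested is made for them only; others in the source may bear on it.

Measured so far:
Compound 1 `OCc1cn(CCNc2nonc2/C(=N/O)Nc2ccc(F)c(Br)c2)nn1`: 794 nM
Compound 2 `OCCCCc1cn(CCNc2nonc2/C(=N/O)Nc2ccc(F)c(Br)c2)nn1`: 1080 nM

In an assay on isolated protein for inhibition of Indoleamine 2,3-dioxygenase 2 (Homo sapiens) (on this read-out higher numbers stand for weaker inhibition and lower numbers for stronger inhibition), compound 2 gives the higher of the two numbers, yet the step of a 1.4-fold higher number from compound 1 to compound 2 (0.13 log units; within the scatter) lies within the scatter, so the two cannot be told apart. Compound 3 `CC(O)c1cn(CCNc2nonc2/C(=N/O)Nc2ccc(F)c(Br)c2)nn1` differs from compound 2 by 1-hydroxyethyl in place of 4-hydroxybutyl on an aromatic carbon. Going by the values given here, the only measured step that bears on this, a 1.4-fold higher number from compound 1 to compound 2 (0.13 log units; within the scatter), also altered the hydroxy-bearing chain at the same place and stayed within the scatter. For compound 3 the expected step is therefore a 1.2-fold lower number from compound 2 to compound 3 (0.08 log units; within the scatter), with no movement beyond the scatter. Compound 3 is estimated at 900 nM, within 400 nM to 2000 nM.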

Compound 3, half-maximal inhibitory concentration: 362 nM
Estimate against measurement, compound 3: 2.5-fold (0.40 log units) above, and the stated range ends above it.
By their numbers in this assay, from the lowest: compound 3; then compounds 1 and 2 (each within the scatter of the next).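

The side chain on this aromatic carbon can move the number beyond the scatter: 1-hydroxyethyl in place of 4-hydroxybutyl gives a 3.0-fold lower number from compound 2 to compound 3 (0.47 log units; beyond the scatter). A single added methyl on the carbon carrying the hydroxy gives a 2.2-fold lower number from compound 1 to compound 3 (0.34 log units; beyond the scatter), whereas the longer chain of compound 2 stayed within the scatter of compound 1. Nothing available here gives a reason for this gain. Still open, as far as these compounds go, is whether an amine in place of the hydroxy, or an ethyl group in place of the added methyl, would keep the stronger inhibition of compound 3.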